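Aryl swap at the aromatic-ring nitrogen of compound 3

The source may hold more compounds than are shown below. What is called first, only, known or untested is meant among the compounds shown, and "the series" means these compounds.

Measured compounds: compound 1 `O=C(CSc1nc(Nc2ccccc2)c2ccccc2n1)Nc1ccccc1Cl`, 14600 nM; compound 2 `COc1cccc(NC(=O)CSc2nc(Nc3ccccc3)c3ccccc3n2)c1`, 11600 nM; compound 3 `C=CC(=O)Nc1cccc(NC(=O)CSc2nc(Nc3cccc(Br)c3)c3ccccc3n2)c1`, 15000 nM.

In a functional assay on PC-3 cells (Homo sapiens) for inhibition, read by MTT assay, with a stated time of 72 h (a higher number here means a weaker inhibitor, a lower number a stronger inhibitor), compound 3 gives 15000 nM, a number that sits alongside those of compound 1 and compound 2, within the scatter of both. Compound 4 `C=CC(=O)Nc1cccc(NC(=O)CSc2nc(Nc3ccc(Cl)c(Cl)c3)c3ccccc3n2)c1` differs from compound 3 in one place: 3,4-dichlorophenyl in place of 3-bromophenyl on a nitrogen on an aromatic ring. Among the compounds with values here, the only measured step, a 1.3-fold lower number from compound 1 to compound 2 (0.10 log units; within the scatter), concerns the amide-type nitrogen, not the nitrogen on an aromatic ring, so no measured step bears directly on this change. Within the data shown here, the three numbers so far hardly move, and for compound 4 no step beyond the scatter is expected, no change at the digits printed from compound 3 to compound 4 (within the scatter). Compound 4 is therefore estimated at 15000 nM in this assay, within 7000 nM to 32000 nM.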

Compound 4, half-maximal inhibitory concentration: 27600 nM
Beside the measured number, compound 4's estimate is 1.8-fold (0.26 log units) below it; the measured number falls inside the stated range.
By their numbers in this assay, from the lowest: compounds 2, 1, 3 and 4 (each within the scatter of the next, the first and the last beyond it).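

In this assay, within the data shown here, there is a 1.8-fold higher number from compound 3 to compound 4 (0.26 log units; within the scatter) when 3,4-dichlorophenyl stands in place of 3-bromophenyl on a nitrogen on an aromatic ring, the first step that can be read at this position. Among these compounds, the earlier step concerned the amide-type nitrogen, so only this pair shows that this exchange of halogen-bearing phenyl groups stays within the scatter. Nothing available explains this step. From the compounds shown here alone, whether a phenyl carrying an amine or a carboxylic acid would give a step beyond the scatter at this nitrogen remains open.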